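One extra methyl on compound 2

This account rests on a few compounds, and the source may have more. Where it says the series, first, only, none or still open, it means among the compounds named here.

In a functional assay on HeLa cells (Homo sapiens) for cytotoxicity, read by MTT assay, with a stated time of 72 h (a higher number here means a weaker inhibitor, a lower number a stronger inhibitor), compound 1 `CCCCC(C)C/C(=C/[C@@]1(CC)OC(=O)C[C@@H]1O)CC` gives 31200 nM and compound 2 `CCCCC(C)CC(O)(/C=C(/CC)[C@@H](O)CC(=O)OC)CC` gives 15500 nM so these two lie within the usual scatter of each other and neither can be ranked over the other. Compound 3 `CCCCC(CC)CC(O)(/C=C(/CC)[C@@H](O)CC(=O)OC)CC` differs from compound 2 by a single change methyl in place of hydrogen on a saturated chain carbon, four bonds along the chain from a double-bonded chain carbon and an oxygen on a saturated carbon with methyl in place of hydrogen on a saturated chain carbon, four bonds along the chain from a double-bonded chain carbon and an oxygen on a saturated carbon. Cut one bond further out, 1-methylpentyl becomes 1-ethylpentyl. Going by the values given here, no measured pair shows what this change does in this assay so the only guide is compound 2 at 15500 nM as the starting point. The estimated step of a 1.2-fold lower number from compound 2 to compound 3 (0.08 log units; within the scatter) is expected to stay within the scatter. For compound 3 the estimated value is 13000 nM with an expected range from 6000 nM to 28000 nM when it is measured.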

Compound 3, half-maximal inhibitory concentration: 15900 nM
Compound 3: the middle estimate sits 1.2-fold (0.09 log units) below what was measured; the range from low to high includes it.
By their numbers in this assay, from the lowest: compounds 2, 3 and 1 (each within the scatter of the next).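

In this assay, going by these compounds alone, the step that turns 1-methylpentyl into 1-ethylpentyl is a 1.0-fold higher number from compound 2 to compound 3 (0.01 log units; within the scatter), the first pair to isolate a single change at this position. It shows that a methyl in place of hydrogen on this saturated chain carbon, four bonds along the chain from a double-bonded chain carbon and an oxygen on a saturated carbon, leaves no readable difference in this assay. Nothing measured here explains why the two compounds read alike.

From the compounds shown here alone, this one pair covers only methyl and ethyl at this place, so a longer chain such as hexyl, or an amine or a carboxylic acid on the same carbon, remains open. Whether the same change would also leave no readable difference on the core of compound 1 is open too.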